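The compounds below may be only part of what the source reports. "The series", "measured", "known", "first", "only" and "open" are said of these compounds alone.

Measured so far in a functional assay on MCF7 cells (Homo sapiens) for cytotoxicity, read by sulforhodamine B assay, with a stated time of 24 h; on this read-out higher numbers stand for weaker inhibition and lower numbers for stronger inhibition
Compound 1 `N=c1oc2ccccc2cc1C(=O)N/N=C1\C(=O)Nc2ccc(S(=O)(=O)N3CCOCC3)cc21` gives 20800 nM
Compound 2 `O=C1Nc2ccc(S(=O)(=O)N3CCOCC3)cc2/C1=N/c1ccc(Br)cc1` gives 44800 nM

Compound 2 stands highest of these two, and its gap to compound 1 lies beyond the scatter, so it is the weaker inhibitor of the pair. Compound 3 `O=C1Nc2ccc(S(=O)(=O)N3CCOCC3)cc2/C1=N/c1ccc(O)cc1` has hydroxy in place of the bromo of compound 2 on an aromatic carbon, para to a large group (hydroxy in place of bromo on an aromatic carbon). Among the compounds with values here, no measured pair shows this change, so in this assay no step beyond the scatter is expected in either direction. The estimated 1.1-fold lower number from compound 2 to compound 3 (0.05 log units; within the scatter) is therefore small. Compound 3 is estimated at 40000 nM (range 15000 nM to 100000 nM).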

Compound 3, half-maximal inhibitory concentration: 52700 nM
Estimate against measurement, compound 3: 1.3-fold (0.12 log units) below; measured number inside the range.
By their numbers in this assay, from the lowest: compound 1; then compounds 2 and 3 (each within the scatter of the next).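

In this assay, hydroxy in place of bromo on the aromatic carbon gives a 1.2-fold higher number from compound 2 to compound 3 (0.07 log units; within the scatter). Within the data shown here, this is the first measured single change at this place, para to a large group, and swapping bromo for hydroxy, with the hydrogen-bond donor and acceptor that hydroxy brings, does not move the number beyond the scatter. No measurement at hand offers an explanation for this result.

The compounds shown leave open whether an amine, a carboxylic acid or a methoxy group at this place would give a step beyond the scatter.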